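Fluorine Added to the Phenyl of Compound 3

The source may hold more compounds than are shown below. What is called first, only, known or untested is meant among the compounds shown, and "the series" means these compounds.

Compound 3 `C/C(=N\Nc1nc(-c2ccccc2)cs1)c1sc(C)nc1C` stands at the edge of a toxicity assay on MCF7 cells (Homo sapiens) for cytotoxicity, read by MTT assay; a higher number here means a weaker inhibitor of growth, a lower number a stronger inhibitor of growth: in this assay compound 3 gives > 100 ug/mL, a limit rather than a number. Compound 1 `C/C(=N\NC(N)=S)c1sc(C)nc1C` gives > 100 ug/mL, also a limit. Compound 2 `C/C(=N\NC(N)=S)c1sc(-c2ccccc2)nc1C` gives 26 ug/mL, and the step of an at least 3.8-fold lower number from compound 1 to compound 2 (0.58 log units; beyond the scatter) moves away from the limit of > 100 ug/mL in this assay, at which 2 of the 3 values shown sit. Compound 4 `C/C(=N\Nc1nc(-c2ccc(F)cc2)cs1)c1sc(C)nc1C` differs from compound 3 by fluoro in place of hydrogen on an aromatic carbon. Among the measured compounds shown here, no measured step involves a fluoro, so the only measured step offers no guide, and compound 3 itself is known only as a limit. The step that the limit leaves unreadable from compound 3 to compound 4 is therefore expected to stay within the scatter. Compound 4 is estimated at 120 ug/mL, between 50 ug/mL and 300 ug/mL, most likely again reported as a limit.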

Compound 4, concentration for 50% growth inhibition: > 100 ug/mL
Compound 4: a limit, no number; the forecaster's own chance of this, stated with the estimate: 75%; the middle value is on the limit's open side.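

In this assay compound 3 and compound 4 are both known only as limits, so no step from one to the other can be read: the limit of > 100 ug/mL in this assay, at which 3 of the 4 values shown sit.

As far as these compounds go, whether fluoro in place of hydrogen on an aromatic carbon changes growth inhibition at all stays open.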